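Longer ester chains on a shared anilinoquinazoline-free core series

A few compounds are considered here, and "the series" means these few. Any claim that something is new, unique, unknown or untested is made for them only; others in the source may bear on it.

Compound 1 `CCCOC(=O)CCC(=O)N1CCN(CCCOc2cc3c(Nc4ccc(F)c(Cl)c4)ncnc3cc2OC)CC1`: 23.4%
Compound 2 `CCCCCCOC(=O)CCC(=O)N1CCN(CCCOc2cc3c(Nc4ccc(F)c(Cl)c4)ncnc3cc2OC)CC1`: 42.9%

Among the measured compounds shown here, in a functional assay on A549 cells (Homo sapiens) for cytotoxicity, read by MTT assay, with a stated time of 24 h, tested at 80 uM (a lower number here means a stronger effect, a higher number a weaker effect of the compound at the concentration tested), compound 2 stands highest of the two numbers; the nearer number is that of compound 1, and the single measured step is a number 19.5 percentage points higher from compound 1 to compound 2 (beyond the scatter). Compound 3 `CCCCCCCCCCOC(=O)CCC(=O)N1CCN(CCCOc2cc3c(Nc4ccc(F)c(Cl)c4)ncnc3cc2OC)CC1` differs from compound 2 by butyl in place of hydrogen on a saturated chain carbon, six bonds along the chain from an oxygen next to a carbonyl group. For the measured compounds named here, only that one step, of propyl in place of hydrogen on the same ester chain, bears on this change; it lay beyond the scatter, so a further lengthening is expected to move in the same direction, by about a number 15.1 percentage points higher from compound 2 to compound 3 (beyond the scatter). Compound 3 is therefore estimated at 58%, between 40% and 78%.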

Compound 3, a percentage reported as activity, at one concentration (the size of the read-out at that concentration, not a potency): 2%
Compound 3: the middle estimate sits 56 percentage points above what was measured; measured number below the stated range.
By their numbers in this assay, from the lowest: compound 3; then compound 1; then compound 2.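

In this assay, butyl in place of hydrogen, on a saturated chain carbon six bonds along the chain from an oxygen next to a carbonyl group, reverses the earlier rise (a number 40.9 percentage points lower from compound 2 to compound 3 (beyond the scatter)). Compound 3 also falls under compound 1 (a number 21.4 percentage points lower from compound 1 to compound 3 (beyond the scatter)), so across these three compounds the number rises and then falls as the ester chain lengthens. Nothing at hand explains this turn.

The compounds shown leave open where between hexyl and the chain of compound 3 the turn lies, and an octyl ester would bear on that. They also leave open how a longer chain, a benzyl ester or a free carboxylic acid would read.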